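Swapping the Sulfonamide Heterocycle on Two Related Cores

The compounds below may be only part of what the source reports. "The series", "measured", "known", "first", "only" and "open" are said of these compounds alone.

Three compounds have been measured in a functional assay on B16-F10 cells (Mus musculus) for cytotoxicity, read by CCK-8 assay, with a stated time of 48 h; on this read-out higher numbers stand for weaker inhibition and lower numbers for stronger inhibition:

Compound 1, `Cc1cc(NS(=O)(=O)c2ccc(/N=C/c3c(Cl)c4cc(C(C)(C)C)cc(C(C)(C)C)c4oc3=O)cc2)no1`, gives 240 nM.
Compound 2, `Cc1ccnc(NS(=O)(=O)c2ccc(/N=C/c3c(Cl)c4cc(C(C)(C)C)cc(C(C)(C)C)c4oc3=O)cc2)n1`, gives 190 nM.
Compound 3, `Cc1ccc2oc(=O)c(/C=N/c3ccc(S(=O)(=O)Nc4cc(C)on4)cc3)c(Cl)c2c1`, gives 250 nM.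

Compound 1 and compound 2 share a core and differ in one place: 4-methylpyrimidin-2-yl in place of 5-methyl-1,2-oxazol-3-yl on a sulfonamide nitrogen. This change produced a 1.3-fold lower number from compound 1 to compound 2 (0.10 log units; within the scatter), so the two numbers cannot be told apart. Compound 3 carries a different core; the difference between the two cores is not broken down here, and its value sits close to those of compound 1 and compound 2.

Compound 4, `Cc1ccc2oc(=O)c(/C=N/c3ccc(S(=O)(=O)Nc4nccc(C)n4)cc3)c(Cl)c2c1`, is compound 3 with the same change applied: 4-methylpyrimidin-2-yl in place of 5-methyl-1,2-oxazol-3-yl on a sulfonamide nitrogen. Both changes sit on a sulfonamide nitrogen whose other neighbour is a sulfonyl sulfur, so this is the same change on a second core. Because the earlier step of a 1.3-fold lower number from compound 1 to compound 2 (0.10 log units; within the scatter) stayed within the scatter, the expected step from compound 3 to compound 4 in this assay is a 1.3-fold lower number from compound 3 to compound 4 (0.10 log units; within the scatter), also within the scatter. Compound 4 is therefore estimated at 200 nM, with a likely range from 100 nM to 400 nM.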

Compound 4, half-maximal inhibitory concentration: 270 nM
Beside the measured number, compound 4's estimate is 1.4-fold (0.13 log units) below it; measured number inside the range.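

In this assay, placing 4-methylpyrimidin-2-yl where 5-methyl-1,2-oxazol-3-yl stood on the sulfonamide nitrogen produced a 1.1-fold higher number from compound 3 to compound 4 (0.03 log units; within the scatter), so these two numbers cannot be told apart. The change therefore left the read-out within the scatter on the second core as well, and the two steps agree: the same change on two cores in this assay, a 1.3-fold lower number (0.10 log units; within the scatter) from compound 1 to compound 2 and a 1.1-fold higher number (0.03 log units; within the scatter) from compound 3 to compound 4, 1.4-fold (0.13 log units) apart, within the scatter of two such steps

Among the compounds shown here, this shows only that swapping these two groups made no measurable difference on either core in this assay. It does not show that a clear effect would carry from one core to another, since neither step is large enough to test that, and it says nothing about other cores or other assays.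

The compounds shown leave open whether a quite different group on the sulfonamide nitrogen, such as a phenyl ring or a longer alkyl chain, would shift the number beyond the scatter. They also leave the contribution of each core difference unresolved, since the two cores differ in more than one place.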